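The source may report more compounds than this note shows. Statements on the series, on what has been measured and on what is new or still open speak of the compounds shown alone.

Of the compounds shown here, three have numbers so far. In a functional assay on MRC5 cells (Homo sapiens) for cytotoxicity (on this read-out higher numbers stand for lower toxicity in this test and lower numbers for higher toxicity in this test), compound 1 `O=C(NNC(=O)c1ccc([N+](=O)[O-])o1)c1ccc([N+](=O)[O-])o1` gives 4000 nM and compound 2 `O=C(Cc1ccccc1)NNC(=O)c1ccc([N+](=O)[O-])o1` gives 2000 nM as its half-maximal cytotoxic concentration. Compound 3 `O=C(NNC(=O)c1ccc([N+](=O)[O-])o1)c1ccc2ccccc2c1` gives 2000 nM in this assay as well, level with compound 2 at the digits available and within the scatter of compound 1. The three numbers do not separate, although the groups on the shared core differ. No two of these compounds differ in one place only, so no measured single change is available as a guide.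

Compound 4 `CC(C)(C)OC(=O)Nc1ccc2cc(C(=O)NNC(=O)c3ccc([N+](=O)[O-])o3)ccc2c1` carries (tert-butoxycarbonyl)amino in place of hydrogen on an aromatic carbon of compound 3, in a six-membered aromatic ring of carbon only that is part of a fused or bridged system of two rings. The counted change is (tert-butoxycarbonyl)amino in place of hydrogen on an aromatic carbon in full.

With compound 1 at 4000 nM and compound 3 at 2000 nM inside the scatter of each other, only a small move toward a higher number is expected in this assay here. The estimated step of a 1.5-fold higher number from compound 3 to compound 4 (0.18 log units; within the scatter) is expected to stay within the scatter. For compound 4 the estimate is 3000 nM with an expected span from 1000 nM to 8000 nM as the range.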

Compound 4, half-maximal cytotoxic concentration: 2000 nM
Beside the measured number, compound 4's estimate is 1.5-fold (0.18 log units) above it; the measured number falls inside the stated range.
By their numbers in this assay, from the lowest: compounds 2, 3, 4 and 1 (each within the scatter of the next).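

In this assay, (tert-butoxycarbonyl)amino in place of hydrogen on an aromatic carbon, at the place meta to a fused ring and para to a fused ring, gives no change at the digits printed from compound 3 to compound 4 (within the scatter). Among these compounds, this is the first single change that can be read, and it shows that this position can carry the whole carbamate-bearing group without the half-maximal cytotoxic concentration leaving the scatter; the earlier compounds differ in more than one place and could not show this for any one position. No accompanying measurement speaks to the reason for this result.

Among the compounds shown here, the single step covers one group at one position, so it remains open whether a free amine or a carboxylic acid at the same aromatic carbon would also stay within the scatter of compound 3. Going by these compounds, it also remains open whether the same (tert-butoxycarbonyl)amino group would leave the number in place at another carbon of that ring, or on the phenylacetyl side of compound 2, where a single step could test the same change on a different partner.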